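Solubility of two measured compounds and one awaited

This account rests on a few compounds, and the source may have more. Where it says the series, first, only, none or still open, it means among the compounds named here.

Compound 1 `CC1SC(c2cccc(C(=O)NCCCCc3ccccc3)c2)N(c2ccc(C3CC3)cc2)C1=O` gives 10000 nM
Compound 2 `COc1ccc(F)cc1N1C(=O)CSC1c1cccc(C(=O)NCCCCc2ccccc2)c1` gives 10000 nM

In a physicochemical assay for solubility, read by turbidimetry, measured as kinetic solubility, at pH 6.8 (on this read-out higher numbers stand for higher solubility and lower numbers for lower solubility), compound 2 gives 10000 nM, level with compound 1 at 10000 nM and within the scatter. Compound 3 `O=C(NCCCCc1ccccc1)c1cccc(C2SCC(=O)N2c2cccc(F)c2)c1` differs from compound 2 in one place, with hydrogen in place of methoxy on an aromatic carbon, taking 5-fluoro-2-methoxyphenyl to 3-fluorophenyl (hydrogen in place of methoxy on an aromatic carbon). Among the compounds with values here, no measured pair shows this change, so no step beyond the scatter is expected in this assay, and the estimated step is no change at the digits printed from compound 2 to compound 3 (within the scatter). Compound 3 is expected at 10000 nM, within an estimated range of 5000 nM to 20000 nM.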

Compound 3, solubility: 10000 nM
Estimate against measurement, compound 3: no gap at the digits printed; measured number inside the range.
By their numbers in this assay, from the lowest: compounds 1, 2 and 3 (each within the scatter of the next).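

In this assay, hydrogen in place of methoxy on an aromatic carbon, taking 5-fluoro-2-methoxyphenyl to 3-fluorophenyl, gives no change at the digits printed from compound 2 to compound 3 (within the scatter). Within the data shown here, this is the only measured step at this position, on the aromatic ring ortho to a large group and para to a fluoro group, and it shows that the read-out stays put when the methoxy leaves. Nothing at hand explains this result. Going by these compounds, whether an amine or a carboxylic acid at this position would leave the read-out equally unmoved stays open, as does the same change on a ring without the fluoro group.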